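This account rests on a few compounds, and the source may have more. Where it says the series, first, only, none or still open, it means among the compounds named here.

The measured compounds in a functional assay on HeLa cells (Homo sapiens) for cytotoxicity, read by MTT assay, with a stated time of 48 h; on this read-out lower numbers stand for stronger inhibition and higher numbers for weaker inhibition:

compound 1, `COc1ccc(-c2nc3ccccn3c2C(=O)/C=C\Nc2ccc3[nH]ccc3c2)cc1`, 13600 nM
compound 2, `COc1ccc(-c2nc3ccccn3c2C(=O)/C=C\Nc2ccc3cc[nH]c3c2)cc1`, 15300 nM
compound 3, `O=C(/C=C\Nc1ccc2[nH]ccc2c1)c1c(-c2ccc(Cl)cc2)nc2ccccn12`, 3240 nM

The account begins with the pair that shares a core. Compound 2 differs from compound 1 by 1H-indol-6-yl in place of 1H-indol-5-yl on an amine nitrogen, and in this assay this gave a 1.1-fold higher number from compound 1 to compound 2 (0.05 log units; within the scatter). The same kind of move on the indole ring therefore left the number essentially where it was.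

Compound 3 carries a different core; the difference from compound 1 is chloro in place of methoxy on an aromatic carbon, and in this assay this gave a 4.2-fold lower number from compound 1 to compound 3 (0.62 log units; beyond the scatter). Compound 3 thus stands with the lowest number of the three, and its steps to the other two are beyond the scatter.

Compound 4, `O=C(/C=C\Nc1ccc2cc[nH]c2c1)c1c(-c2ccc(Cl)cc2)nc2ccccn12`, has not yet been measured. It differs from compound 3 by 1H-indol-6-yl in place of 1H-indol-5-yl on an amine nitrogen, the same change already seen between compound 1 and compound 2, at the same place on an amine nitrogen whose other neighbours are a double-bonded chain carbon. Since that earlier change gave a 1.1-fold higher number from compound 1 to compound 2 (0.05 log units; within the scatter), the expectation for compound 4 rests on the step from compound 3 being of similar size, and the step is estimated as a 1.1-fold higher number from compound 3 to compound 4 (0.05 log units; within the scatter). Compound 4 is therefore expected to give about 3600 nM in this assay, with the estimate placed between 1800 nM and 7500 nM.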

Compound 4, half-maximal inhibitory concentration: 10900 nM
For compound 4 the middle estimate is 3.0-fold (0.48 log units) below the measured one; the measured number lies above the stated range.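

In this assay the swap of 1H-indol-5-yl for 1H-indol-6-yl on an amine nitrogen did not carry over unchanged from one core to the other, since on the chloro-bearing core it gave a 3.4-fold higher number from compound 3 to compound 4 (0.53 log units; beyond the scatter), and the two steps differ: the same change on two cores in this assay, a 1.1-fold higher number (0.05 log units; within the scatter) from compound 1 to compound 2 and a 3.4-fold higher number (0.53 log units; beyond the scatter) from compound 3 to compound 4, 3.0-fold (0.48 log units) apart, beyond the scatter of two such steps

Read along the other edge of the same four compounds, chloro in place of methoxy on an aromatic carbon gave a 1.4-fold lower number from compound 2 to compound 4 (0.15 log units; within the scatter) when the indole was 1H-indol-6-yl, and this too differs from its earlier counterpart: the same change on two cores in this assay, a 4.2-fold lower number (0.62 log units; beyond the scatter) from compound 1 to compound 3 and a 1.4-fold lower number (0.15 log units; within the scatter) from compound 2 to compound 4, 3.0-fold (0.48 log units) apart, beyond the scatter of two such steps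

Both gaps rest on the same four numbers and so form a single observation: the two changes do not simply add up here, but this does not show what lies behind that, nor whether it holds beyond these four compounds.

On these data alone, it remains open whether the lower number of compound 3 belongs to chloro paired with 1H-indol-5-yl specifically, or would also appear with fluoro, bromo or methyl on that aromatic carbon. Also open, as far as these compounds go, is how an indol-4-yl group or a plain phenyl on the amine nitrogen would behave with either methoxy or chloro.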